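Carboxyphenyl in place of cyanopyridyl at the distal aryl

The compounds below may be only part of what the source reports. "The series", "measured", "known", "first", "only" and "open" are said of these compounds alone.

Within the data shown here, compound 2 `CCC(C)(C)Cc1c[nH]c(CCc2ccc(-c3cccc(C#N)n3)cc2)n1` gives 115 nM in a functional assay on HEK293 cells for agonist activity at Bombesin receptor subtype-3 (Mus musculus), read by luminescence and calcium flux, with a stated time of 10 min (a higher number here means that more compound is needed for the effect, a lower number that less compound is needed), the highest of the two numbers measured so far; its nearest neighbour is compound 1 `CCC(C)(C)Cc1c[nH]c(CCc2ccc(-n3cccn3)cc2)n1`, which in this assay gives 113 nM. Among the measured compounds shown here, the single measured step, a 1.0-fold higher number from compound 1 to compound 2 (0.01 log units; within the scatter), lies within the scatter. Compound 3 `CCC(C)(C)Cc1c[nH]c(CCc2ccc(-c3ccccc3C(=O)O)cc2)n1` carries 2-carboxyphenyl in place of 6-cyanopyridin-2-yl on an aromatic carbon. For the measured compounds named here, only that one step bears on this change, and it was flat, while a carboxyl-bearing group has no measured precedent here; the expected step is therefore a 1.7-fold higher number from compound 2 to compound 3 (0.24 log units; within the scatter), with wide uncertainty. For compound 3 the estimate is 200 nM, within a range of 60 nM to 900 nM.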

Compound 3, half-maximal effective concentration: 94 nM
Beside the measured number, compound 3's estimate is 2.1-fold (0.33 log units) above it; measured number inside the range.
By their numbers in this assay, from the lowest: compounds 3, 1 and 2 (each within the scatter of the next).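

In this assay, this place on the six-membered aromatic ring of carbon only also accepts 2-carboxyphenyl, with its hydrogen-bond donor: the change gives a 1.2-fold lower number from compound 2 to compound 3 (0.09 log units; within the scatter) and, against the other group, a 1.2-fold lower number from compound 1 to compound 3 (0.08 log units; within the scatter). The three groups, 1H-pyrazol-1-yl, 6-cyanopyridin-2-yl and 2-carboxyphenyl, are therefore not separated by this read-out. No measured data explain this tolerance.

From the compounds shown here alone, it remains open whether an aminomethyl group or the methyl ester of the carboxylic acid would stay at the same level at this place.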